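Ethyl to cyclopropyl on the shared core

A few compounds are considered here, and "the series" means these few. Any claim that something is new, unique, unknown or untested is made for them only; others in the source may bear on it.

Compound 1 `COC(=O)c1nc(C)n(-c2cccc(Br)c2)n1` reaches only the limit > 100000 nM in a functional assay on Jurkat cells (Homo sapiens) for inhibition, read by MTT assay, with a stated time of 72 h; a lower number here means a stronger inhibitor of growth, a higher number a weaker inhibitor of growth. For the measured compounds named here, compound 2 `COC(=O)c1nc(C)n(-c2cccc(C(F)(F)F)c2)n1` gives 10600 nM in this assay; the move is an at least 9.4-fold lower number from compound 1 to compound 2 (0.97 log units; beyond the scatter), and the only evidence touching it is the limit of > 100000 nM in this assay, at which 1 of the 3 values shown sits. Going by the values given here, compound 3 `CCc1nc(C(=O)OC)nn1-c1ccc(F)cc1` gives 11000 nM in this assay; that number sits with the one for compound 2 within the scatter, so no order between these two is claimed.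

Compound 4 `COC(=O)c1nc(C2CC2)n(-c2ccc(F)cc2)n1` differs from compound 3 by cyclopropyl in place of ethyl on an aromatic carbon. Among the compounds with values here, no measured step bears on this kind of change: the single step in hand, an at least 9.4-fold lower number from compound 1 to compound 2 (0.97 log units; beyond the scatter), concerns trifluoromethyl in place of bromo and says nothing about the group carried by the five-membered aromatic ring with 3 nitrogen. With nothing to lean on, the change is expected to give a step of a 1.1-fold lower number from compound 3 to compound 4 (0.04 log units; within the scatter), within the scatter. Compound 4 is accordingly estimated at 10000 nM, in a range of 4000 nM to 25000 nM, in this assay.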

Compound 4, concentration for 50% growth inhibition: 9420 nM
Beside the measured number, compound 4's estimate is 1.1-fold (0.03 log units) above it, and the stated range covers the measured number.
By their numbers in this assay, from the lowest: compounds 4, 2 and 3 (each within the scatter of the next). At a limit, above all of these: compound 1.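

This position, on an aromatic carbon between two ring nitrogen atoms, now has its first measured step: cyclopropyl in place of ethyl gives a 1.2-fold lower number from compound 3 to compound 4 (0.07 log units; within the scatter) in this assay. The earlier step concerned only trifluoromethyl in place of bromo, whereas this one shows that a three-membered ring of carbon can replace the two-carbon ethyl group here without a change beyond the scatter, at least with the methoxycarbonyl group and the group of 7 heavy atoms held as in compound 3. Nothing measured here gives a reason for this step or ties it to any property of either group.

On these data alone, what a longer chain such as butyl, or an amine, would give at this position remains open. Also open, as far as these compounds go, is whether a carboxylic acid in place of the methoxycarbonyl group would leave the number where it stands.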